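Swapping isopropyl for cyclopropyl on the oxygen of compound 1

This account rests on a few compounds, and the source may have more. Where it says the series, first, only, none or still open, it means among the compounds named here.

Measured in a functional assay on MV4-11 cells (Homo sapiens) for antiproliferative activity, read by CCK-8 assay, with a stated time of 72 h (on this read-out higher numbers stand for weaker inhibition and lower numbers for stronger inhibition), so far
- compound 1 `CC(C)Oc1ccc(C(C)(C)O)cc1-c1cn(C)c(=O)c2[nH]c(C(=O)NCc3ccc(C(=O)Nc4ccccc4N)cc3)cc12` gives 40 nM
- compound 2 `CC(C)Oc1ccccc1-c1cn(C)c(=O)c2[nH]c(C(=O)NCc3ccc(C(=O)Nc4ccccc4N)cc3)cc12` gives 130 nM
- compound 3 `CC(C)Oc1ccc(C(C)(C)O)cc1-c1cn(C)c(=O)c2[nH]c(C(=O)NCc3ccc(C(=O)NO)cc3)cc12` gives 350 nM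

Of these three, compound 1 has the lowest number (40 nM), the mark of the strongest inhibition here. Compound 4 `Cn1cc(-c2cc(C(C)(C)O)ccc2OC2CC2)c2cc(C(=O)NCc3ccc(C(=O)Nc4ccccc4N)cc3)[nH]c2c1=O` differs from it in one place (cyclopropyl in place of isopropyl on an oxygen on an aromatic ring), with cyclopropyl in place of isopropyl on an oxygen on an aromatic ring. Neither measured step changes that group. The two steps (a 3.3-fold higher number from compound 1 to compound 2 (0.51 log units; beyond the scatter)) and (an 8.8-fold higher number from compound 1 to compound 3 (0.94 log units; beyond the scatter)) lie elsewhere and show only how far changes at other places have moved the number. In this assay the expected step (a 1.3-fold higher number from compound 1 to compound 4 (0.10 log units; within the scatter)) therefore stays within the scatter, with no firm direction. Compound 4 is estimated at 50 nM (expected range 20 nM to 130 nM).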

Compound 4, half-maximal inhibitory concentration: 40 nM
Estimate against measurement, compound 4: 1.3-fold (0.10 log units) above, and the stated range covers the measured number.
By their numbers in this assay, from the lowest: compounds 1 and 4 (each within the scatter of the next); then compound 2; then compound 3.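

In this assay, going by these compounds alone, the first change at this position, cyclopropyl in place of isopropyl on the oxygen, gives no change at the digits printed from compound 1 to compound 4 (within the scatter). The earlier steps shown here moved the number only through changes elsewhere, whereas this one shows that a three-membered ring can stand here, with the same count of heavy atoms, without a change beyond the scatter. No measurement shown here explains why the two groups read alike. From the compounds shown here alone, what remains open is how a methyl, a longer chain such as butyl, or an amine-bearing chain on this oxygen would read. Going by these compounds, it also remains open whether the swap would read the same alongside the other changes.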